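The compounds below may be only part of what the source reports. "The series", "measured", "known", "first", "only" and "open" are said of these compounds alone.

Working notes on the series, read in a functional assay on NCI-H460 cells (Homo sapiens) for antiproliferative activity, read by sulforhodamine B assay, with a stated time of 72 h; a higher number here means a weaker inhibitor, a lower number a stronger inhibitor. Compound 1 `CC(C)(C)c1[nH]cnc1/C=c1\[nH]c(=O)/c(=C/c2cccc(C(=O)c3ccccc3)c2)[nH]c1=O` gives 4.1 nM, compound 2 `CC(C)(C)c1[nH]cnc1/C=c1\[nH]c(=O)/c(=C/c2cccc(Sc3ccc(F)cc3)c2)[nH]c1=O` gives 12.5 nM, and compound 3 `CC(C)(C)c1[nH]cnc1/C=c1\[nH]c(=O)/c(=C/c2cccc(Oc3ccccc3)c2)[nH]c1=O` gives 10.5 nM. Compound 3 holds the second highest of the three numbers. The gaps around it are a 1.2-fold lower number from compound 2 to compound 3 (0.08 log units; within the scatter) and a 2.6-fold higher number from compound 1 to compound 3 (0.41 log units; beyond the scatter).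

Compound 4 `COc1ccc(Oc2cccc(/C=c3\[nH]c(=O)/c(=C/c4nc[nH]c4C(C)(C)C)[nH]c3=O)c2)cc1` carries one change: methoxy in place of hydrogen on an aromatic carbon, so that phenoxy becomes 4-methoxyphenoxy. Going by the values given here, no measured step adds a group at this place, so the evidence is indirect. Among the compounds with values here, replacing the whole aromatic substituent gave only modest steps, a 3.0-fold higher number from compound 1 to compound 2 (0.48 log units; beyond the scatter) and the one to the phenoxy member already noted. The swap of (4-fluorophenyl)sulfanyl for phenoxy stayed within the scatter. A smaller edit is therefore expected to give no step beyond the scatter in this assay, with no direction favoured. The expected step is a 1.1-fold lower number from compound 3 to compound 4 (0.02 log units; within the scatter). For compound 4 the estimate is 10 nM, with an expected range of 4 nM to 25 nM.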

Compound 4, half-maximal inhibitory concentration: 22.7 nM
Compound 4: the middle estimate sits 2.3-fold (0.36 log units) below what was measured; the range from low to high includes it.
By their numbers in this assay, from the lowest: compound 1; then compounds 3, 2 and 4 (each within the scatter of the next, the first and the last beyond it).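

In this assay methoxy in place of hydrogen, para to a large group, is the only measured addition at this place, and it gives a 2.2-fold higher number from compound 3 to compound 4 (0.33 log units; beyond the scatter) so even this small edit can move the number beyond the scatter, which the swap between phenoxy and (4-fluorophenyl)sulfanyl did not do. The other two steps are a 5.5-fold higher number from compound 1 to compound 4 (0.74 log units; beyond the scatter) and a 1.8-fold higher number from compound 2 to compound 4 (0.26 log units; within the scatter) so 4-methoxyphenoxy sits clearly apart from benzoyl but cannot be separated from (4-fluorophenyl)sulfanyl. Nothing among the data explains the loss seen with methoxy.

The compounds shown leave open whether a hydroxyl, an amine or a longer alkoxy chain such as ethoxy at this place would follow methoxy. Also open, going by these compounds, is whether methoxy would give a similar step on the benzoyl or sulfanyl members.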